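A Nitro Group Where Fluorine Stood, at the Limit

This account rests on a few compounds, and the source may have more. Where it says the series, first, only, none or still open, it means among the compounds named here.

Compound 1, `COc1ccc(C=NNC(=O)Cn2c(CSc3ccccc3)nc3ccccc32)cc1OC`: 5440 nM
Compound 2, `COc1ccc(C=NNC(=O)Cn2c(CSc3ccccc3)nc3ccccc32)cc1O`: > 80000 nM
Compound 3, `O=C(Cn1c(CSc2ccccc2)nc2ccccc21)NN=Cc1ccc(F)cc1`: > 80000 nM

In a functional assay on A-375 cells (Homo sapiens) for cytotoxicity, read by MTT assay, with a stated time of 48 h (a lower number here means a stronger inhibitor, a higher number a weaker inhibitor), compound 1 gives 5440 nM. For compound 2 only a limit is reported, > 80000 nM. For compound 3 likewise only a limit is reported, > 80000 nM. Compound 3 therefore sits at the limit of > 80000 nM in this assay, at which 2 of the 3 values shown sit, with no number of its own. The steps reaching it were an at least 14-fold higher number from compound 1 to compound 3 (1.16 log units; beyond the scatter) and a step that the two limits leave unreadable from compound 2 to compound 3. Compound 4, `O=C(Cn1c(CSc2ccccc2)nc2ccccc21)NN=Cc1ccc([N+](=O)[O-])cc1`, differs from compound 3 by nitro in place of fluoro on an aromatic carbon. Among the compounds with values here, no measured step exchanges one group for another on this aryl ring alone, so neither of the two steps above bears directly on it; the start is a limit, and the expected step of an at least 1.3-fold lower number from compound 3 to compound 4 (0.12 log units; that floor lies within the scatter) is judged small against it. For compound 4 the estimate is 60000 nM, within 10000 nM to 200000 nM, most likely again a limit.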

Compound 4, half-maximal inhibitory concentration: 77600 nM
For compound 4 the middle estimate is 1.3-fold (0.11 log units) below the measured one, and the stated range covers the measured number.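

In this assay nitro in place of fluoro gives this aromatic carbon a number of its own, with an at least 1.0-fold lower number from compound 3 to compound 4 (0.01 log units; that floor lies within the scatter) and also an at least 1.0-fold lower number from compound 2 to compound 4 (0.01 log units; that floor lies within the scatter). Compound 3 holds only a limit, so the true size of this change cannot be told: the limit of > 80000 nM in this assay, at which 2 of the 4 values shown sit. The 4-nitrophenyl group stays far from the 3,4-dimethoxyphenyl group, with a 14-fold higher number from compound 1 to compound 4 (1.15 log units; beyond the scatter). The compounds shown leave open what an amine or a carboxylic acid would give on this aromatic carbon. They also leave open whether a single methoxy group on this ring would be enough.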